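N-Methylation of a bridged amine in a nicotinic agonist series

The source may hold more compounds than are shown below. What is called first, only, known or untested is meant among the compounds shown, and "the series" means these compounds.

The study compares compounds built on a shared bicyclic core and follows one change from compound 1 `Fc1ccc(C2=CC3CNCC(C2)C3)cn1`. In an in vitro functional assay on SH-SY5Y cells for agonist activity at Neuronal acetylcholine receptor; alpha3/beta4 (Homo sapiens), read by FLIPR and calcium flux (a lower number here means a smaller maximal response, a higher number a larger maximal response), compound 1 gives 140%. Among the measured compounds shown here, only one other compound has been measured: compound 2 `C1=C(c2cncnc2)CC2CNCC1C2`, which in this assay gives 147%; the two numbers differ by an amount that lies within the usual scatter, so neither can be placed above the other. Compound 3 `CN1CC2C=C(c3ccc(F)nc3)CC(C2)C1` is the next compound, and it differs from compound 1 in one place: methyl in place of hydrogen on an amine nitrogen in a ring. For the measured compounds named here, no step between two measured compounds bears on this change, so the expectation rests on compound 1 alone. Compound 3 is expected to give a somewhat smaller maximal response than compound 1, a step of a number 20 percentage points lower from compound 1 to compound 3 (beyond the scatter). For compound 3 in this assay the estimate is 120%, with a range from 70% to 160%.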

Compound 3, largest response reached (reported as percent of maximum), in percent of the reference or control that the assay uses: 25%
Beside the measured number, compound 3's estimate is 95 percentage points above it; measured number outside the range, below it.
By their numbers in this assay, from the lowest: compound 3; then compounds 1 and 2 (each within the scatter of the next).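

In this assay, methyl in place of hydrogen on the amine nitrogen in the ring gives a number 115 percentage points lower from compound 1 to compound 3 (beyond the scatter), a large step for an addition of 1 heavy atom. The earlier compounds shown here both carry hydrogen on this nitrogen and so said nothing about substitution there, whereas this pair shows that, with the rest of compound 1 unchanged, the maximal response depends strongly on what sits at this position. The data offer no measurement that accounts for the size of this step.

On these data alone, whether a longer chain such as ethyl or propyl, or an acetyl group, on the same nitrogen would give a similar response remains open. As far as these compounds go, it is also open whether the same methyl would bring a step of similar size on compound 2, whose other part differs.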